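Removing the Naphthyl Ester: A Step Toward the Assay Limit

The compounds below may be only part of what the source reports. "The series", "measured", "known", "first", "only" and "open" are said of these compounds alone.

Of the compounds shown here, three sharing one core have been tested in a functional assay on MDA-MB-231 cells (Homo sapiens) for cytotoxicity, read by MTT assay, with a stated time of 48 h; a lower number here means a stronger inhibitor, a higher number a weaker inhibitor. Compound 1 `O=C(NCc1ccccc1)c1cn(-c2ccccc2)nc1-c1ccncc1` gives > 100000 nM in this assay, which is a limit of the assay and not a number. Compound 2 `CC(C)(C)c1ccc(OC(=O)c2cn(-c3ccccc3)nc2-c2ccncc2)cc1` gives 34500 nM in this assay. Compound 3 `O=C(Oc1ccc2ccccc2c1)c1cn(-c2ccccc2)nc1-c1ccncc1` gives > 100000 nM in this assay, again a limit rather than a number. Among the measured compounds shown here, the one measured step at the oxygen next to the carbonyl group, an at least 2.8-fold higher number from compound 2 to compound 3 (0.46 log units; beyond the scatter), already went in the weakening direction. Compound 3 therefore stands at the weak end of what is shown; together with compound 1 it sits at the limit of > 100000 nM in this assay, at which 2 of the 3 values shown sit. Compound 4 `O=C(O)c1cn(-c2ccccc2)nc1-c1ccncc1` differs from compound 3 by hydrogen in place of naphthalen-2-yl on an oxygen next to a carbonyl group. For the measured compounds named here, only the step from compound 2 to compound 3 bears on changes at this oxygen, and no measured step shows a return from the limit to a number. The expected step in this assay is therefore a step that the limit leaves unreadable from compound 3 to compound 4, leaving the value at or beyond the limit. The estimated value for compound 4 is 150000 nM, with a range from 40000 nM to 600000 nM.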

Compound 4, half-maximal inhibitory concentration: > 100000 nM
Compound 4 ended at the assay's limit; the forecaster's own chance of this, stated with the estimate: 75%; the middle value is on the limit's open side.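

Taking the group off this oxygen altogether does not bring back a readable value: compound 4 gives > 100000 nM in this assay, which is a limit of the assay and not a number. Hydrogen in place of 4-(tert-butyl)phenyl gives an at least 2.8-fold higher number from compound 2 to compound 4 (0.46 log units; beyond the scatter), the same direction as the change to naphthalen-2-yl, so among the compounds that differ only on this oxygen, compound 2 alone still gives a number. The steps to compound 4 from compound 1 and from compound 3 cannot be read, because both ends of each are limits: the limit of > 100000 nM in this assay, at which 3 of the 4 values shown sit.

Going by these compounds, what a plain phenyl or a methyl group would give on this oxygen remains open. Also open, on these data alone, is how far past the limit compound 3 and compound 4 lie, so no order between them can be given.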